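A few compounds are considered here, and "the series" means these few. Any claim that something is new, unique, unknown or untested is made for them only; others in the source may bear on it.

Measured so far in an ADME assay on Raji cells (Homo sapiens) for cytotoxicity, read by CellTiter-Glo, with a stated time of 72 h; on this read-out lower numbers stand for an effect already at smaller amounts and higher numbers for an effect only at larger amounts of compound:
compound 1 `C=C1/C=C/C(C)(C)CC2=C(C)C(=O)[C@]3(C[C@@H](C)C=C3/C=C\1C)O2`: 26000 nM
compound 2 `CC1=C2CC(C)(C)/C=C/C/C(C)=C\C3=C[C@H](C)C[C@]3(O2)C1=O`: 26000 nM
compound 3 `CC(=O)O[C@@H]1/C=C/C(C)(C)CC2=C(C)C(=O)[C@]3(C[C@@H](C)C=C3/C=C\1C)O2`: 26000 nM

Compound 2, at 26000 nM, stands level with compound 1 and compound 3. Compound 4 `CC1=C2CC(C)(C)/C=C/[C@H](OC(=S)Sc3ccccc3)/C(C)=C\C3=C[C@H](C)C[C@]3(O2)C1=O` differs from it by a group of 10 heavy atoms (7 carbon, 1 oxygen, 2 sulfur; one six-membered aromatic ring of carbon only) in place of a hydrogen atom, on a saturated ring carbon, next to the ring atom that bears a methyl group. Within the data shown here, one measured step bears on this change: no change at the digits printed from compound 2 to compound 3 (within the scatter), with acetoxy in place of hydrogen on a saturated ring carbon. Among the measured compounds shown here, no measured compound carries the entering group, so the range stays wide. Even so, no step beyond the scatter is expected in this assay. The estimated step is a 1.3-fold lower number from compound 2 to compound 4 (0.11 log units; within the scatter). Compound 4 is expected at 20000 nM, within an estimated range of 6000 nM to 40000 nM.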

Compound 4, half-maximal effective concentration: 26000 nM
Compound 4: the middle estimate sits 1.3-fold (0.11 log units) below what was measured, within the range that was stated.
By their numbers in this assay, from the lowest: compounds 1, 2, 3 and 4 (each within the scatter of the next).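

In this assay, a group of 10 heavy atoms with a six-membered aromatic ring of carbon only, on the saturated ring carbon next to the ring atom that bears a methyl group, gives no change at the digits printed from compound 2 to compound 4 (within the scatter). The position therefore tolerates not only acetoxy but also this much larger group without a step beyond the scatter. Nothing at hand explains why the read-out stays level. On these data alone, whether an amine or a carboxylic acid on this carbon would move the number in this assay stays open.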